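Piperidin-1-yl in place of pyrrolidin-1-yl: series notes

This account rests on a few compounds, and the source may have more. Where it says the series, first, only, none or still open, it means among the compounds named here.

Three compounds carry numbers in a functional assay on MES-SA/Dx5 cells (Homo sapiens) for inhibition, with a stated time of 72 h; a higher number here means a weaker inhibitor, a lower number a stronger inhibitor. Compound 1 `Oc1c(CN2CCCC2)ccc2cccnc12` gives 1470 nM; 1450 nM (2 entries), and its repeat entries agree closely (the several entries of compound 1 in this assay, 1470 nM; 1450 nM (2 entries)). Compound 2 `Oc1c(CN2CCCCC2)ccc2cccnc12` gives 850 nM; 832 nM (2 entries), again with close repeats (the several entries of compound 2 in this assay, 850 nM; 832 nM (2 entries)). Compound 3 `COCc1cc(CN2CCCC2)c(O)c2ncccc12` gives 1350 nM, the only number shown for it, alongside two further entries without a single number. These three values lie within the usual scatter of one another, so no order can be read among them.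

The next compound is compound 4 `COCc1cc(CN2CCCCC2)c(O)c2ncccc12`, which has piperidin-1-yl in place of pyrrolidin-1-yl on a saturated chain carbon bound to an aromatic carbon. Going by the values given here, no step between measured compounds is available to size this exchange directly. Among the compounds with values here, the expectation therefore rests on the narrow spread of the values so far, with compound 2 at 850 nM; 832 nM (2 entries) and compound 3 at 1350 nM lying within the scatter of each other. No change beyond the scatter is expected in this assay. The expected move is a 1.4-fold lower number from compound 3 to compound 4 (0.15 log units; within the scatter), which would stay within the scatter. For compound 4 the estimated value is 950 nM, with an expected range of 480 nM to 1900 nM.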

Compound 4, half-maximal inhibitory concentration: 912 nM
Compound 4: the middle estimate sits 1.0-fold (0.02 log units) above what was measured; the range from low to high includes it.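

In this assay, the exchange of pyrrolidin-1-yl for piperidin-1-yl on a saturated chain carbon bound to an aromatic carbon now has a direct reading: a 1.5-fold lower number from compound 3 to compound 4 (0.17 log units; within the scatter). This position therefore takes the six-membered ring with 6 heavy atoms in place of the five-membered ring with 5 without a change that can be read, and the two groups count as equivalent in this assay on this core. Repeat entries in the series agree closely, so the small size of this step is not an artefact of noisy entries, though that agreement comes from other compounds: the several entries of compound 1 in this assay, 1470 nM; 1450 nM (2 entries)

Still open, as far as these compounds go, is whether a ring with a second hetero atom, such as morpholin-4-yl, or an open-chain amine, such as diethylamino, on the same carbon would move the number beyond the scatter. Also open is how the exchange from pyrrolidin-1-yl to piperidin-1-yl reads in any setting other than this assay, since the compounds shown give numbers in this assay only.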